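Sulfonamide nitrogen swap from compound 2 to compound 3

The source may report more compounds than this note shows. Statements on the series, on what has been measured and on what is new or still open speak of the compounds shown alone.

In a functional assay on cells (leukaemia cell line, Homo sapiens) for inhibition, read by sulforhodamine B assay, with a stated time of 48 h (on this read-out higher numbers stand for lower toxicity in this test and lower numbers for higher toxicity in this test), compound 1 (`O=S(=O)(Nc1cccc(Cl)c1)c1ccc(-c2cnc(C3CC3)o2)cc1`) gives > 100000 nM as a limit and not a number. Compound 2 (`Cc1ccc(NS(=O)(=O)c2ccc(-c3cnc(C4CC4)o3)cc2)cc1C`) likewise gives > 100000 nM as a limit in this assay and has no exact position in the series. For the measured compounds named here, the only measured step is a step that the two limits leave unreadable from compound 1 to compound 2 and it offers no size to carry forward. Compound 3 (`O=S(=O)(Nc1ccc(F)cc1F)c1ccc(-c2cnc(C3CC3)o2)cc1`) has 2,4-difluorophenyl in place of 3,4-dimethylphenyl on a sulfonamide nitrogen and keeps the core of compound 1. No step beyond the scatter is expected in this assay and no direction can be assigned, because the limit of > 100000 nM in this assay, at which 2 of the 2 values shown sit, is the whole of the evidence so far. The estimated step is a number no higher from compound 2 to compound 3 (the limit leaves the size open) on this reading. For compound 3 the expected value is 100000 nM within an estimated range of 40000 nM to 200000 nM and another limit is the likeliest report.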

Compound 3, concentration lethal to 50% of the cells: > 100000 nM
Compound 3 gave a limit, no number (the forecaster's own chance of this, stated with the estimate: 85%); the middle value lies on the limit itself.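

Compound 3 gives > 100000 nM as a limit and not a number. With compound 1 and compound 2 also reported as limits, no step among these three compounds can be read. As far as these compounds go, how far the 3-chlorophenyl, 3,4-dimethylphenyl and 2,4-difluorophenyl groups on a sulfonamide nitrogen separate in this assay remains open.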